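A few compounds are considered here, and "the series" means these few. Any claim that something is new, unique, unknown or untested is made for them only; others in the source may bear on it.

Measured in an ADME assay on Vero cells (Chlorocebus sabaeus) for inhibition, read by CellTiter-Glo, with a stated time of 2 days (a lower number here means a stronger inhibitor, a higher number a weaker inhibitor), all three as limits:
Compound 1 `NC(=O)c1sc(N2CCCCC2)cc1OCCc1ccccc1`: > 100000 nM
Compound 2 `NC(=O)c1sc(N2CCOCC2=O)cc1OCCc1ccccc1`: > 100000 nM
Compound 3 `NC(=O)c1sc(-n2cnc3ccccc32)cc1OCCc1ccccc1`: > 100000 nM

Compound 1 has no number, only a limit of > 100000 nM. The other two measured compounds stand in the same place, as the limit of > 100000 nM in this assay, at which 3 of the 3 values shown sit, records.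

Compound 4 `NC(=O)c1sc(-c2ccncc2)cc1OCCc1ccccc1` keeps the core of compound 1 and carries pyridin-4-yl in place of piperidin-1-yl on an aromatic carbon. Within the data shown here, the one measured step that bears on this change is a step that the two limits leave unreadable from compound 1 to compound 2, and it gives no size to carry over. Compound 3 also yields only a limit, > 100000 nM. On these readings, no shift beyond the scatter is expected in this assay, in either direction, and another limit is the likeliest report. The estimated step is a number no higher from compound 1 to compound 4 (the limit leaves the size open). The expected value for compound 4 is 100000 nM, with an estimated range of 40000 nM to 200000 nM.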

Compound 4, half-maximal inhibitory concentration: 5900 nM
Beside the measured number, compound 4's estimate is 17-fold (1.23 log units) above it, outside the stated range (below it).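

In this assay, compound 4 is the only compound shown that gives a number, so the group on the aromatic carbon next to the ring sulfur can move the read-out, while the other three compounds stay at a limit: the limit of > 100000 nM in this assay, at which 3 of the 4 values shown sit. Pyridin-4-yl in place of piperidin-1-yl gives an at least 16-fold lower number from compound 1 to compound 4 (1.22 log units; beyond the scatter), and pyridin-4-yl in place of 3-oxomorpholin-4-yl gives an at least 16-fold lower number from compound 2 to compound 4 (1.22 log units; beyond the scatter). Piperidin-1-yl and pyridin-4-yl match in heavy atoms, hydrogen-bond donors and acceptors and net charge and differ in whether the ring is aromatic, yet compound 3, also aromatic at this place, gives no number and so goes against any rule based on aromaticity alone.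

The steps among the three limits cannot be read, so these compounds do not rank them. The compounds shown also leave open whether the ring nitrogen of pyridin-4-yl matters, which a phenyl or a pyridin-3-yl group at this place would test.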